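A Second Fluoro on the Aryl Ring of Compound 1

A few compounds are considered here, and "the series" means these few. Any claim that something is new, unique, unknown or untested is made for them only; others in the source may bear on it.

Compound 1 `CC(=O)Nc1cc(-c2ccc(OC[C@@H](N)CC(C)C)c(F)c2)ccn1` is the reference point of this short series. Within the data shown here, in an assay on HEK293F cells for inhibition of AP2-associated protein kinase 1 (Homo sapiens), read by Western blot, with a stated time of 3 h (a lower number here means a stronger inhibitor, a higher number a weaker inhibitor), compound 1 gives 1.6 nM, the highest of the three numbers measured so far. Compound 2 `CC(=O)Nc1cc(-c2ccc(OC[C@@H](N)CC(C)C)c(C)c2)ccn1` carries a methyl where compound 1 has its fluoro. In this assay compound 2 gives 1.1 nM; the step of a 1.5-fold lower number from compound 1 to compound 2 (0.16 log units; within the scatter) lies within the scatter. Compound 3 `CC(=O)Nc1cc(-c2ccc(OC[C@@H](N)CC(C)C)c(Cl)c2)ccn1` carries a chloro at that carbon and gives 0.2 nM; here the step of an 8.0-fold lower number from compound 1 to compound 3 (0.90 log units; beyond the scatter) is beyond the scatter, as is a 5.5-fold lower number from compound 2 to compound 3 (0.74 log units; beyond the scatter). All three measured steps thus swap one group for another at a single aromatic carbon.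

Compound 4 `CC(=O)Nc1cc(-c2cc(F)c(OC[C@@H](N)CC(C)C)cc2F)ccn1` differs from compound 1 in another way: fluoro in place of hydrogen on an aromatic carbon. The entering fluoro sits on an aromatic carbon ortho to a large group and para to a fluoro group, so the original fluoro of compound 1 stays in place. Among the measured compounds shown here, no measured step describes adding a second substituent to this ring, so the swaps among fluoro, methyl and chloro give only indirect guidance and no direction can be read from them. Compound 4 is therefore expected to land close to compound 1, with the step of no change at the digits printed from compound 1 to compound 4 (within the scatter) expected to stay within the scatter. The estimate for compound 4 is 1.6 nM, with a range from 0.5 nM to 5 nM.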

Compound 4, half-maximal inhibitory concentration: 6.7 nM
Compound 4: the middle estimate sits 4.2-fold (0.62 log units) below what was measured, outside the stated range (above it).
By their numbers in this assay, from the lowest: compound 3; then compounds 2 and 1 (each within the scatter of the next); then compound 4.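

In this assay, among these compounds, this is the first step that adds a substituent to the aryl ring instead of swapping one, and placing a fluoro in place of hydrogen on the carbon ortho to a large group and para to a fluoro group gives a 4.2-fold higher number from compound 1 to compound 4 (0.62 log units; beyond the scatter). This shows that the carbon does not tolerate the change silently, even for a single fluoro, whereas the earlier swaps at the carbon holding the original fluoro stayed within the scatter or went the other way, as in an 8.0-fold lower number from compound 1 to compound 3 (0.90 log units; beyond the scatter). Nothing in the data shown accounts for this rise.

The compounds shown leave open whether the higher number belongs to the new fluoro alone or to its pairing with the original fluoro, and whether a methoxy group or a nitrile at the same carbon would move the number in the same direction. They also leave open whether the chloro of compound 3 would keep its low number with a fluoro at this carbon.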